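Replacing bromo with dimethylamino on compound 2

The compounds below may be only part of what the source reports. "The series", "measured", "known", "first", "only" and "open" are said of these compounds alone.

Compound 1 `CC(C)(C)n1cc2c(n1)C(=O)CC1(CCN(C(=O)c3cc(-c4ccccc4Cl)nc4ccccc34)CC1)O2` and compound 2 `CC(C)(C)n1cc2c(n1)C(=O)CC1(CCN(C(=O)c3cc(-c4ccc(Br)cc4)nc4ccccc34)CC1)O2` share one core and carry different substituted phenyl groups. In a functional assay on HepG2 cells (Homo sapiens) for inhibition, read by MTT assay, with a stated time of 72 h (on this read-out lower numbers stand for stronger inhibition and higher numbers for weaker inhibition), compound 1 gives > 10000 nM as a limit of the assay, not a number. In this assay, within the data shown here, compound 2 gives 820 nM and so holds the only true number so far. Among the measured compounds shown here, the single measured step of an at least 12-fold lower number from compound 1 to compound 2 (1.08 log units; beyond the scatter) is large, and it replaced 2-chlorophenyl with 4-bromophenyl. Compound 3 `CN(C)c1ccc(-c2cc(C(=O)N3CCC4(CC3)CC(=O)c3nn(C(C)(C)C)cc3O4)c3ccccc3n2)cc1` has dimethylamino in place of bromo on an aromatic carbon and otherwise matches compound 2. That one step suggests the phenyl group can matter, but it changed the halogen and its place together, so it bears only loosely on this swap. A smaller move with a slight lean to weaker inhibition is expected, estimated as a 1.8-fold higher number from compound 2 to compound 3 (0.26 log units; within the scatter) in this assay for this swap. For compound 3 the estimated value is 1500 nM with an expected range from 400 nM to 6000 nM in this measurement.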

Compound 3, half-maximal inhibitory concentration: 1730 nM
Compound 3: the middle estimate sits 1.2-fold (0.06 log units) below what was measured; low and high end bracket the measured number.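

In this assay, the swap of bromo for dimethylamino at the same place on the phenyl group gives a 2.1-fold higher number from compound 2 to compound 3 (0.32 log units; beyond the scatter), so two quite different groups at this place both leave a measurable number, with only a modest loss of inhibition between them. The comparison with the 2-chlorophenyl compound now has a second member, an at least 5.7-fold lower number from compound 1 to compound 3 (0.76 log units; beyond the scatter), which again favours a group at the 4-position of the phenyl. That step can only be read as a minimum, since compound 1 stands at a limit of the assay, not a number: the limit of > 10000 nM in this assay, at which 1 of the 3 values shown sits.

As far as these compounds go, how a smaller group such as methoxy, or a carboxylic acid, would behave at this place remains open. Also open, from the compounds shown here alone, is whether the 2-chloro group loses inhibition through the chlorine itself or through its place on the ring, since both differ at once.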